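This account rests on a few compounds, and the source may have more. Where it says the series, first, only, none or still open, it means among the compounds named here.

For the measured compounds named here, compound 1 `CCCCCCCCCCCCC(C)(C)C(=O)Nc1c(C)cc(C)c2c1OC(C)(C)C2` gives 33 nM in an assay for inhibition of acyl-CoA:cholesterol acyltransferase (Oryctolagus cuniculus), using microsomes (on this read-out higher numbers stand for weaker inhibition and lower numbers for stronger inhibition), the lowest number among the three measured members. Compound 2 `Cc1cc(C)c(NC(=O)C(C)(C)CCCCc2ccccc2)c2c1CC(C)(C)O2` gives 210 nM in this assay, and compound 3 `Cc1cc(C)c(NC(=O)C(C)(C)CCCCCCOc2ccc(Cl)cc2)c2c1CC(C)(C)O2` gives 76 nM in this assay. Compound 4 `Cc1ccc(OCCCCCCC(C)(C)C(=O)Nc2c(C)cc(C)c3c2OC(C)(C)C3)cc1` is not yet measured; it differs from compound 1 in that (4-methylphenoxy in place of hexyl on a saturated chain carbon, seven bonds along the chain from a carbonyl carbon). The most direct precedent is a 2.3-fold higher number from compound 1 to compound 3 (0.36 log units; beyond the scatter), the same place on the chain and a related group entering. Less direct is a 6.4-fold higher number from compound 1 to compound 2 (0.80 log units; beyond the scatter), where the ring enters at a different place on the chain. Both precedents point to a modest rise in the number. For compound 4 a step of a 2.1-fold higher number from compound 1 to compound 4 (0.33 log units; beyond the scatter) in this assay is therefore expected. The estimate for compound 4 is 70 nM, with a range of 35 nM to 150 nM.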

Compound 4, half-maximal inhibitory concentration: 50 nM
Estimate against measurement, compound 4: 1.4-fold (0.15 log units) above; low and high end bracket the measured number.
By their numbers in this assay, from the lowest: compounds 1, 4 and 3 (each within the scatter of the next, the first and the last beyond it); then compound 2.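

In this assay, 4-methylphenoxy in place of hexyl, seven bonds along the chain from a carbonyl carbon, is not separated from compound 1 (a 1.5-fold higher number from compound 1 to compound 4 (0.18 log units; within the scatter)), whereas the 4-chlorophenoxy step from compound 1 is printed as beyond the scatter. Methyl in place of chloro on the aromatic carbon is likewise unresolved (a 1.5-fold lower number from compound 3 to compound 4 (0.18 log units; within the scatter)), while the gap to the phenyl chain is beyond the scatter (a 4.2-fold lower number from compound 2 to compound 4 (0.62 log units; beyond the scatter)). No measured evidence here explains these steps.

Still open, as far as these compounds go, is whether an amine or a carboxylic acid on that aromatic carbon would move the number beyond the scatter. A longer chain before the phenoxy oxygen also remains untested in the compounds shown.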